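This account rests on a few compounds, and the source may have more. Where it says the series, first, only, none or still open, it means among the compounds named here.

Of the compounds shown here, two have been tested so far in a functional assay on the whole organism for inhibition, with Rattus norvegicus as the target, at a dose of 25 mg/kg by the intraperitoneal route; a lower number here means less inhibition, a higher number more inhibition at the dose given (going by the name of the read-out). Compound 1, `CN(C)c1ncnc2c1ncn2Cc1ccccc1[N+](=O)[O-]`, gives 0% in this assay. Compound 2, `c1nc(N2CCC2)c2ncn(CC3CC3)c2n1`, gives 30% in this assay. Of these two numbers, compound 2 stands highest, and its nearest neighbour, compound 1, lies below it by a gap that is beyond the usual scatter of repeated measurements. Compound 1 and compound 2 differ in more than one place, so the gap between them cannot be tied to any single structural feature; the two values simply show where each compound stands.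

Compound 3, `c1nc(NC2CCC2)c2ncn(CC3CC3)c2n1`, has not yet been measured. It is compound 2 with one change: cyclobutylamino in place of azetidin-1-yl on an aromatic carbon. Among the measured compounds shown here, no measured pair shows this kind of change, so nothing in the data says how it will act. The step from compound 2 to compound 3 is therefore expected to be small, in either direction, and likely to stay within the scatter, with no change at the digits printed from compound 2 to compound 3 (within the scatter) as the expected size. Compound 3 is estimated to give 30% in this assay, with a range from 5% to 55%.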

Compound 3, a percentage reported as inhibition, in the whole organism at one dose (the size of the read-out at that dose, not a potency): 0%
The estimate for compound 3 lay 30 percentage points above the measured number; measured number below the stated range.
By their numbers in this assay, from the lowest: compounds 1 and 3 (each within the scatter of the next); then compound 2.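

In this assay the replacement of azetidin-1-yl by cyclobutylamino on this aromatic carbon gives a number 30 percentage points lower from compound 2 to compound 3 (beyond the scatter) and so shows that the read-out at this dose responds to a change at this position. This holds even though both groups carry a four-membered ring and a single nitrogen, so sharing those features does not keep the number in place. The two groups still differ in several ways at once: cyclobutylamino has one more heavy atom, a hydrogen-bond donor that azetidin-1-yl lacks, and a ring of carbon only, and nothing available indicates which of these differences matters.

The compounds shown leave open whether the number would return if cyclobutylamino carried a methyl group on its nitrogen, a swap that would remove the donor while keeping the carbon-only ring. They also leave open how a larger ring on nitrogen, such as pyrrolidin-1-yl or piperidin-1-yl, or an open-chain dimethylamino group, would behave at this position alongside the cyclopropylmethyl group of compound 2.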